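Aryl replacement at the ortho position of the shared core

The compounds below may be only part of what the source reports. "The series", "measured", "known", "first", "only" and "open" are said of these compounds alone.

Measured compounds:
compound 1 `CC(Oc1ccccc1-c1ccccc1O)C1=NCCN1`: 1000 nM
compound 2 `CC(Oc1ccccc1-c1cccnc1)C1=NCCN1`: 933 nM
compound 3 `Cc1cccc(-c2ccccc2OC(C)C2=NCCN2)c1`: 537 nM

All three were run in an assay on CHO cells for displacement of a labelled ligand from Alpha-2B adrenergic receptor (Homo sapiens); a higher number here means a weaker inhibitor, a lower number a stronger inhibitor. Compound 3 has the lowest number of the three, yet the steps reaching it are small: a 1.9-fold lower number from compound 1 to compound 3 (0.27 log units; within the scatter) and a 1.7-fold lower number from compound 2 to compound 3 (0.24 log units; within the scatter), both within the scatter, as is a 1.1-fold lower number from compound 1 to compound 2 (0.03 log units; within the scatter). Compound 4 `CC(Oc1ccccc1-c1cccs1)C1=NCCN1` differs from compound 3 by thiophen-2-yl in place of 3-methylphenyl on an aromatic carbon. Going by the values given here, no measured step swaps in a thiophen-2-yl; the two steps at the same aromatic carbon, from compound 1 and from compound 2 to compound 3, change the aryl group and stay within the scatter. On that basis compound 4 is expected to show a step of a 1.3-fold higher number from compound 3 to compound 4 (0.12 log units; within the scatter) in this assay, not beyond the scatter. The estimate for compound 4 is 700 nM, within 300 nM to 1600 nM.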

Compound 4, inhibition constant: 214 nM
Compound 4: middle estimate off by 3.3-fold (0.51 log units), on the high side; the measured number lies below the stated range.
By their numbers in this assay, from the lowest: compound 4; then compounds 3, 2 and 1 (each within the scatter of the next).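

At this aromatic carbon, the aryl group can shift the number in this assay: thiophen-2-yl gives a 2.5-fold lower number from compound 3 to compound 4 (0.40 log units; beyond the scatter) and a 4.4-fold lower number from compound 2 to compound 4 (0.64 log units; beyond the scatter) and a 4.7-fold lower number from compound 1 to compound 4 (0.67 log units; beyond the scatter) as steps beyond the scatter, while compounds 1, 2 and 3, with six-membered aromatic rings here, remain within the scatter of one another. Compound 4 is the only one here with a five-membered aromatic ring at this position, so ring size and the sulfur cannot be told apart. Nothing available accounts for these steps.

Open, as far as these compounds go, is whether furan-2-yl or thiophen-3-yl would match thiophen-2-yl. Also open, from the compounds shown here alone, is whether a methyl group or a chlorine on the thiophene ring would keep the lower number.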